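The source may report more compounds than this note shows. Statements on the series, on what has been measured and on what is new or still open speak of the compounds shown alone.

Measured compounds:
Compound 1, `CCCNc1nc(Nc2ccc(C#N)cc2)nc(Oc2ccc3cc(Br)ccc3c2Br)n1`, in an ADME assay on MT4 cells (Homo sapiens) for cytotoxicity, read by MTT assay, with a stated time of 4 days (a lower number here means that less compound is tolerated, a higher number that more compound is tolerated), compound 1 gives 134000 nM.
Compound 2, `CC(C)Nc1nc(Nc2ccc(C#N)cc2)nc(Oc2ccc3ccccc3c2Br)n1`, in this assay compound 2 gives 41500 nM.
Compound 3, `CNc1nc(Nc2ccc(C#N)cc2)nc(Oc2ccc3ccccc3c2Br)n1`, in this assay compound 3 gives 143000 nM.

Compound 3 has the highest number of the three, meaning the most compound is tolerated by the cells. Its value and that of compound 1 lie within the scatter of each other, so no order between them can be claimed; compound 2 stands clearly lower, as the step of a 3.4-fold higher number from compound 2 to compound 3 (0.54 log units; beyond the scatter) shows.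

Compound 4, `CCCNc1nc(Nc2ccc(C#N)cc2)nc(Oc2ccc3ccccc3c2Br)n1`, is not yet measured. It differs from compound 3 in one place: ethyl in place of hydrogen on a saturated chain carbon bound to a nitrogen on an aromatic ring. Seen one bond further out, the change reads methylamino to propylamino.

Within the data shown here, only one measured step touches the same position: a 3.4-fold higher number from compound 2 to compound 3 (0.54 log units; beyond the scatter), where a larger branched group on that nitrogen went with a lower number. Among the measured compounds shown here, compound 1 also carries a propylamino group, and its value sits close to that of compound 3, though compound 1 differs elsewhere as well, so no step is counted for that pair. Weighing the two, a modest drop from compound 3 to compound 4 is expected, a 1.5-fold lower number from compound 3 to compound 4 (0.18 log units; within the scatter), with a wide range.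

Compound 4 is therefore estimated at 95000 nM, between 40000 nM and 200000 nM.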

Compound 4, half-maximal cytotoxic concentration: > 263000 nM
Compound 4: no number, only a limit (the forecaster's own chance of this, stated with the estimate: 5%); middle value at least 2.7-fold (0.44 log units) away from the limit.
By their numbers in this assay, from the lowest: compound 2; then compounds 1 and 3 (each within the scatter of the next). At a limit, above all of these: compound 4.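

In this assay compound 4 gives > 263000 nM, which is a limit of the assay and not a number: the limit of > 263000 nM in this assay, at which 1 of the 4 values shown sits. Until now, the only step at this nitrogen paired a larger group with a lower number, but here the change from isopropyl to propyl gives an at least 6.3-fold higher number from compound 2 to compound 4 (0.80 log units; beyond the scatter), while the change from methylamino to propylamino gives an at least 1.8-fold higher number from compound 3 to compound 4 (0.26 log units; that floor lies within the scatter), so among these compounds a larger group on the nitrogen does not by itself go with a lower number, and compound 2, with its branched isopropyl, is the one that goes against any simple rule based on size. The hydrogen in place of bromo on an aromatic carbon gives an at least 1.9-fold higher number from compound 1 to compound 4 (0.29 log units; that floor lies within the scatter), and since that floor lies within the scatter, this bromo is not shown to change how much compound the cells tolerate.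

From the compounds shown here alone, how far the true value of compound 4 lies past its limit remains unknown, so these steps give only floors. Also open, going by these compounds, is whether a longer chain such as butyl, a ring such as cyclopropyl, or a chain ending in an amine on that nitrogen would follow compound 2 or compound 4.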